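Triazole thioacetanilides: phenyl in place of trimethoxyphenyl

A few compounds are considered here, and "the series" means these few. Any claim that something is new, unique, unknown or untested is made for them only; others in the source may bear on it.

Three members of the series have so far been tested in a functional assay on the whole organism (strain albino) for inhibition, with Rattus norvegicus as the target, read by paw edema, with stated times of 30 min and 4 h, at a dose of 0.28 mmol/kg by the oral route; a higher number here means more inhibition at the dose given (going by the name of the read-out), a lower number less inhibition. Compound 1 `C=CCn1c(SCC(=O)Nc2ccc(C(C)=O)cc2)nnc1-c1ccccc1` gives 70%. Compound 2 `C/C(=N\O)c1ccc(NC(=O)CSc2nnc(-c3ccccc3)n2-c2ccccc2)cc1` gives 67%. Compound 3 `COc1cc(-c2nnc(SCC(=O)Nc3ccc(C(C)=O)cc3)n2-c2ccccc2)cc(OC)c1OC` gives 68%. Compound 3 stands second highest of the three numbers; its nearest neighbour is compound 2 and its furthest is compound 1, and both gaps lie within the scatter, so none of the three readings can be ordered against another. Among the compounds with values here, no two of the measured compounds differ in a single place, so no step in this assay can be read off directly.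

Compound 4 `CC(=O)c1ccc(NC(=O)CSc2nnc(-c3ccccc3)n2-c2ccccc2)cc1` is awaiting measurement. It differs from compound 3 in one place: phenyl in place of 3,4,5-trimethoxyphenyl on an aromatic carbon. Nothing in the data separates the three measured compounds, whatever groups sit on the shared core, and compound 2, which also carries a phenyl group here and a phenyl group on the ring nitrogen, gives 67%. On that basis the step from compound 3 to compound 4 is expected to be none beyond the scatter, no change at the digits printed from compound 3 to compound 4 (within the scatter). Compound 4 is accordingly estimated at 68%, with a range from 58% to 77%.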

Compound 4, a percentage reported as inhibition, in the whole organism at one dose (the size of the read-out at that dose, not a potency): 67%
Compound 4: middle estimate off by 1 percentage points, on the high side; the range from low to high includes it.
By their numbers in this assay, from the lowest: compounds 2, 4, 3 and 1 (each within the scatter of the next).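

In this assay, within the data shown here, phenyl in place of 3,4,5-trimethoxyphenyl on the aromatic carbon of the shared core gives a number 1 percentage points lower from compound 3 to compound 4 (within the scatter) and is the first single change read at this position, so the loss of all three methoxy groups leaves no step beyond the scatter. Among these compounds, compound 4 also opens two other places: a group of 3 heavy atoms in place of a group of 4 heavy atoms on an aromatic carbon gives no change at the digits printed from compound 2 to compound 4 (within the scatter) and phenyl in place of allyl on an aromatic nitrogen gives a number 3 percentage points lower from compound 1 to compound 4 (within the scatter) in this series, so all three single changes now readable stay within the scatter, with no compound going against that. Nothing measured on these compounds accounts for this result.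

Going by these compounds, all of these steps rest on one oral dose, so it remains open whether they would stay within the scatter at other doses. On these data alone, it also remains open whether this aromatic carbon accepts a group without an aromatic ring, such as an amine or a carboxylic acid, and whether a longer chain in place of allyl on the aromatic nitrogen would move the number beyond the scatter.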